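The compounds below may be only part of what the source reports. "The series", "measured", "known", "first", "only" and "open" are said of these compounds alone.

Measured in a functional assay on B16 cells (Mus musculus) for inhibition; on this read-out lower numbers stand for stronger inhibition and higher numbers for weaker inhibition:
compound 1 `COc1cc(/C=C/C(=O)c2cccc(NC(=O)c3cccs3)c2)ccc1O`: 6.93 ug/mL
compound 2 `COc1cc(/C=C/C(=O)c2cccc(N)c2)ccc1O`: 11.5 ug/mL
compound 3 `CCCC(=O)Nc1cccc(C(=O)/C=C/c2ccc(O)c(OC)c2)c1`: 1.43 ug/mL

Compound 3 carries the lowest number of the three, and its steps to both others lie beyond the scatter. Compound 4 `COc1cc(/C=C/C(=O)c2cccc(NC(C)=O)c2)ccc1O` departs from it in one place: hydrogen in place of ethyl on a saturated chain carbon bound to a carbonyl carbon. This turns propylcarbonyl into acetyl. Going by the values given here, no measured step makes this exact change, but two come close. The first is an 8.0-fold lower number from compound 2 to compound 3 (0.91 log units; beyond the scatter), where propylcarbonyl takes the place of hydrogen on the nitrogen. The second is a 4.8-fold lower number from compound 1 to compound 3 (0.69 log units; beyond the scatter), where propyl takes the place of thiophen-2-yl on the carbonyl carbon. Both show that the group on this nitrogen can move the number by a modest amount. Acetyl keeps the carbonyl of compound 3 and loses only part of the chain, so compound 4 is expected to lose part of that gain, not all of it. The expected move is a modest one, a 2.4-fold higher number from compound 3 to compound 4 (0.39 log units; beyond the scatter). For compound 4 the estimated value is 3.5 ug/mL, with an expected range from 1.3 ug/mL to 9 ug/mL.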

Compound 4, half-maximal inhibitory concentration: 3.62 ug/mL
Beside the measured number, compound 4's estimate is 1.0-fold (0.01 log units) below it; low and high end bracket the measured number.
By their numbers in this assay, from the lowest: compound 3; then compounds 4, 1 and 2 (each within the scatter of the next, the first and the last beyond it).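

In this assay, shortening propylcarbonyl to acetyl gives a 2.5-fold higher number from compound 3 to compound 4 (0.40 log units; beyond the scatter) while the carbonyl stays in place, so the length of the chain on this carbonyl carbon moves the number by itself. Acetyl in place of hydrogen on the nitrogen still gives a 3.2-fold lower number from compound 2 to compound 4 (0.50 log units; beyond the scatter) and so keeps part of the gain seen with propylcarbonyl. Methyl in place of thiophen-2-yl on the carbonyl carbon gives a 1.9-fold lower number from compound 1 to compound 4 (0.28 log units; within the scatter) and thus does not separate these two groups, whereas propyl in the same place was separated from thiophen-2-yl.

The compounds shown leave open whether a chain longer than propyl on this carbonyl carbon would lower the number further or raise it again, and what an amine or a carboxylic acid at the chain end would do. Nothing given here bears on what lies behind these steps.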